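Butyl to isobutyl on a shared core

A few compounds are considered here, and "the series" means these few. Any claim that something is new, unique, unknown or untested is made for them only; others in the source may bear on it.

In a functional assay on the whole organism with Scenedesmus acutus as the target (on this read-out lower numbers stand for stronger inhibition and higher numbers for weaker inhibition), compound 1 (`COC(=O)c1cc(N2C(=O)C3=C(CCCC3)C2=O)c(F)cc1Cl`) gives 110 nM and compound 2 (`CCCCOC(=O)c1cc(N2C(=O)C3=C(CCCC3)C2=O)c(F)cc1Cl`) gives 67.6 nM. These two values lie within the usual scatter of each other, so compound 2 stands level with compound 1. Compound 3 (`CC(C)COC(=O)c1cc(N2C(=O)C3=C(CCCC3)C2=O)c(F)cc1Cl`) has the same atoms as compound 2, joined differently: isopropyl in place of propyl on a saturated chain carbon bound to an oxygen next to a carbonyl group. In other words, isopropyl takes the place of propyl on a saturated chain carbon bound to an oxygen next to a carbonyl group, turning butyl into isobutyl. Within the data shown here, only one measured step bears on this, a 1.6-fold lower number from compound 1 to compound 2 (0.21 log units; within the scatter), which put propyl in place of hydrogen at that carbon. No branched chain has been measured yet. With that single guide, no step beyond the scatter is expected in this assay. The expected change is a 1.0-fold higher number from compound 2 to compound 3 (0.02 log units; within the scatter). Compound 3 is estimated at 70 nM, with an expected range of 35 nM to 140 nM.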

Compound 3, half-maximal inhibitory concentration: 33.1 nM
Compound 3: middle estimate off by 2.1-fold (0.33 log units), on the high side; the whole stated range lies above it.
By their numbers in this assay, from the lowest: compound 3; then compounds 2 and 1 (each within the scatter of the next).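

In this assay, rearranging the butyl chain into isobutyl adds no atoms, yet it gives a 2.0-fold lower number from compound 2 to compound 3 (0.31 log units; beyond the scatter). So the shape of the chain at this position can shift the read-out, a modest effect that the earlier within-scatter step to compound 2 could not establish. Compared with the smallest ester, the isobutyl chain gives a 3.3-fold lower number from compound 1 to compound 3 (0.52 log units; beyond the scatter), which leaves compound 3 with the lowest number of the three. Nothing available explains why the branched chain gives a lower number.

One pair of isomeric chains cannot show whether branching in general lowers the number. From the compounds shown here alone, it remains open how a neopentyl chain, a longer chain such as hexyl, or a ring such as cyclopentyl would behave at this position.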